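This account rests on a few compounds, and the source may have more. Where it says the series, first, only, none or still open, it means among the compounds named here.

Measured so far in a functional assay on HepG2 cells (Homo sapiens) for cytotoxicity, read by MTT assay, with a stated time of 48 h; on this read-out higher numbers stand for weaker inhibition and lower numbers for stronger inhibition:
- compound 1, `CCCCCCCCCCCCCCNC(=O)[C@@H](NC(=O)c1cccs1)[C@@H](C)O`: 88400 nM
- compound 2, `CCCCCCCCCCCCCCCCCCNC(=O)[C@@H](NC(=O)c1ccco1)[C@@H](C)O`: 42300 nM

Compound 2 holds the lowest of the two numbers; the nearest is compound 1, and that gap lies beyond the scatter. No one-place step between measured compounds exists, so the two values are simply stated side by side and no cause is assigned.

Compound 3, `CCCCCCCCCCCCCCCCCCNC(=O)[C@@H](NC(=O)c1cccs1)[C@@H](C)O`, is still unmeasured. Against compound 2 it carries thiophen-2-yl in place of furan-2-yl on a carbonyl carbon, leaving the long chain and the threonine-derived amide untouched.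

For the measured compounds named here, no measured pair isolates this exchange. The expectation for this assay is a step of no clear direction, most likely within the scatter, as the counted difference is small. Compound 3 is therefore expected to give about 45000 nM, in the range 20000 nM to 100000 nM, which means an expected step of a 1.1-fold higher number from compound 2 to compound 3 (0.03 log units; within the scatter).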

Compound 3, half-maximal inhibitory concentration: 92000 nM
For compound 3 the middle estimate is 2.0-fold (0.31 log units) below the measured one, within the range that was stated.
By their numbers in this assay, from the lowest: compound 2; then compounds 1 and 3 (each within the scatter of the next).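

In this assay, for the compounds shown here, thiophen-2-yl in place of furan-2-yl on a carbonyl carbon gives a 2.2-fold higher number from compound 2 to compound 3 (0.34 log units; beyond the scatter) and this is a modest step beyond the scatter, the first reading of this exchange on a pair that differs in one place. With thiophen-2-yl on the carbonyl carbon, butyl in place of hydrogen on a saturated chain carbon gives a 1.0-fold higher number from compound 1 to compound 3 (0.02 log units; within the scatter) and this step stays within the scatter. No measurement at hand offers a cause for either step.

As far as these compounds go, whether the furan-2-yl to thiophen-2-yl exchange gives a similar step on the shorter chain of compound 1 stays open, as does the chain step with furan-2-yl on the carbonyl carbon. Also open, from the compounds shown here alone, is how phenyl or pyridin-2-yl in place of thiophen-2-yl on a carbonyl carbon would read.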